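This account rests on a few compounds, and the source may have more. Where it says the series, first, only, none or still open, it means among the compounds named here.

Measured in a functional assay on LoVo cells (Homo sapiens) for cytotoxicity, read by MTT assay, with a stated time of 72 h; on this read-out higher numbers stand for weaker inhibition and lower numbers for stronger inhibition:
compound 1, `Cc1ccc2[nH]c(-n3cccn3)c(C3=C(Br)C(=O)NC3=O)c2c1`, gives 27000 nM
compound 2, `Cc1ccc2[nH]c3c4cn[nH]c4c4c(c3c2c1)C(=O)NC4=O`, gives 5000 nM
compound 3, `O=C1NC(=O)c2c1c1[nH]ncc1c1[nH]c3ccccc3c21`, gives 44000 nM

Compound 4, `O=C1NC(=O)C(c2c(-n3cccn3)[nH]c3ccccc23)=C1Br`, is not yet measured in this assay. It differs from compound 1 by hydrogen in place of methyl on an aromatic carbon. The same kind of change separates compound 2 from compound 3, (hydrogen in place of methyl on an aromatic carbon); the place differs only in that the ring sits in a fused system of two rings in compound 1 but of five rings in compound 2. The difference between the core of compound 1 and the core of compound 2 is not broken down here. In this assay the change gave an 8.8-fold higher number from compound 2 to compound 3 (0.94 log units; beyond the scatter). Going by the values given here, the step from compound 1 to compound 4 is expected to go the same way, an estimated 3.0-fold higher number from compound 1 to compound 4 (0.47 log units; beyond the scatter), resting on the single precedent an 8.8-fold higher number from compound 2 to compound 3 (0.94 log units; beyond the scatter); the cores differ, so less weight is put on it. Compound 4 is thus estimated at 80000 nM, expected to lie between 30000 nM and 250000 nM.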

Compound 4, half-maximal inhibitory concentration: 24000 nM
Beside the measured number, compound 4's estimate is 3.3-fold (0.52 log units) above it, outside the stated range (below it).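

In this assay, hydrogen in place of methyl on an aromatic carbon gives a 1.1-fold lower number from compound 1 to compound 4 (0.05 log units; within the scatter), so on the core of compound 1 this change shows no step beyond the scatter. The size of the step does not carry from one core to the other in this series: the same change on two cores in this assay, an 8.8-fold higher number (0.94 log units; beyond the scatter) from compound 2 to compound 3 and a 1.1-fold lower number (0.05 log units; within the scatter) from compound 1 to compound 4, 9.9-fold (1.00 log units) apart, beyond the scatter of two such steps

With a single pair on each core, this shows that a step read on one core is a poor guide to the other, but it does not show which difference between the cores goes with the gap, or how the change would read on any further core.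

Still open, from the compounds shown here alone, is how an amine or a methoxy group at this place would read on either core.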